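The source may hold more compounds than are shown below. What is called first, only, known or untested is meant among the compounds shown, and "the series" means these compounds.

In an assay on isolated protein for displacement of a labelled ligand from Motilin receptor (Homo sapiens) (on this read-out lower numbers stand for stronger inhibition and higher numbers for weaker inhibition), compound 1 `CCC[C@@H]1NC(=O)[C@@H](Cc2ccccc2)NC(=O)[C@@H](Cc2ccc(O)cc2)NCCOc2ccccc2/C=C/CNC1=O` gives 1520 nM, and compound 2 `CCC[C@@H]1NC(=O)[C@@H](C(C)C)NC(=O)[C@@H](Cc2ccc(O)cc2)NCCOc2ccccc2CCCNC1=O` gives 55 nM. Compound 3 `CCC[C@@H]1NC(=O)[C@@H](C(C)C)NC(=O)[C@@H](c2ccccc2)NCCOc2ccccc2CCCNC1=O` reaches only > 10000 nM, which is a limit of the measurement and not a number. Among the measured compounds shown here, the one measured step that bears on the change ahead is an at least 180-fold higher number from compound 2 to compound 3 (2.25 log units; beyond the scatter), in which a 4-hydroxybenzyl group on a saturated ring carbon gave way to phenyl; because compound 3 sits at the limit of > 10000 nM in this assay, at which 1 of the 3 values shown sits, the true size of that step is only bounded from below. Compound 4 `CCC[C@@H]1NC(=O)[C@@H](C(C)C)NC(=O)[C@@H](Cc2csc3ccccc23)NCCOc2ccccc2CCCNC1=O` differs from compound 3 by (1-benzothiophen-3-yl)methyl in place of phenyl on a saturated ring carbon, restoring an aromatic group held on a methylene. Compound 4 is therefore expected to recover much of the lost binding, an estimated at least 66-fold lower number from compound 3 to compound 4 (1.82 log units; beyond the scatter), to about 150 nM, between 30 nM and 1500 nM.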

Compound 4, inhibition constant: 11 nM
The estimate for compound 4 lay 14-fold (1.13 log units) above the measured number; the measured number lies below the stated range.
By their numbers in this assay, from the lowest: compound 4; then compound 2; then compound 1. At a limit, above all of these: compound 3.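

Replacing the 4-hydroxyphenyl of compound 2 with 1-benzothiophen-3-yl gives a 5.0-fold lower number from compound 2 to compound 4 (0.70 log units; beyond the scatter), so the hydroxyl is not needed for binding at this ring carbon, and a larger two-ring aromatic group is accepted there. Setting an aromatic group back on a methylene gives an at least 900-fold lower number from compound 3 to compound 4 (2.95 log units; beyond the scatter), and this size is only a lower bound because compound 3 sits at a limit: the limit of > 10000 nM in this assay, at which 1 of the 4 values shown sits.

The compounds shown leave open whether the sulfur matters, which a naphthalen-1-ylmethyl or indol-3-ylmethyl group could test. They also leave open whether a longer chain carrying the 1-benzothiophen-3-yl is accepted.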